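A few compounds are considered here, and "the series" means these few. Any claim that something is new, unique, unknown or untested is made for them only; others in the source may bear on it.

Compound 1, with the structure `Nc1ncnc2c1c(-c1ccc(Oc3ccccc3)cc1)cn2C[C@H]1CCCN1C(CO)CO`, was tested in a functional assay on JeKo-1 cells (Homo sapiens) for antiproliferative activity (on this read-out lower numbers stand for stronger inhibition and higher numbers for weaker inhibition), and gave 14500 nM. Among the compounds with values here, of the two compounds measured so far, compound 1 has the higher number; the other, compound 2 with the structure `CC(C)(C)c1ccc(C(=O)Nc2ccc(-c3cn([C@H]4CCN(C[C@@H]5CO5)C4)c4ncnc(N)c34)cc2)cc1`, gave 3290 nM in this assay, a lower number that lies beyond the scatter, so compound 2 inhibits the growth of these cells more strongly than compound 1 does.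

Compound 3, with the structure `Nc1ncnc2c1c(-c1ccc(Oc3ccccc3)cc1)cn2C[C@H]1CCCN1C[C@@H]1CO1`, has not yet been measured. It differs from compound 1 in one place: (oxiran-2-yl)methyl in place of 2-hydroxy-1-(hydroxymethyl)ethyl on an amine nitrogen in a ring. Within the data shown here, no measured pair of compounds shows this exact change, so its effect cannot be read directly from the numbers at hand.

The expected step from compound 1 to compound 3 is a 3.6-fold lower number from compound 1 to compound 3 (0.56 log units; beyond the scatter), towards stronger inhibition, which is a guess rather than something the data secure. Compound 3 is therefore estimated to give 4000 nM in this assay, within a range from 1000 nM to 15000 nM.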

Compound 3, half-maximal inhibitory concentration: 11100 nM
Beside the measured number, compound 3's estimate is 2.8-fold (0.44 log units) below it, and the stated range covers the measured number.
By their numbers in this assay, from the lowest: compound 2; then compounds 3 and 1 (each within the scatter of the next).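

In this assay, putting (oxiran-2-yl)methyl in place of 2-hydroxy-1-(hydroxymethyl)ethyl on the amine nitrogen in the ring gives a 1.3-fold lower number from compound 1 to compound 3 (0.12 log units; within the scatter) and so leaves the two compounds indistinguishable on this read-out. Within the data shown here, this is the first pair that differs in one place, and it shows that an open chain with 2 hydrogen-bond donors and a three-membered ring with 0 hydrogen-bond donors can occupy this position with no step beyond the scatter. Nothing at hand explains this result.

On these data alone, whether an amine or a carboxylic acid on a longer chain at this nitrogen would give a step beyond the scatter stays open. Among these compounds, also open is whether this same exchange gives so small a step on any other core, as only one pair can be read so far.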